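From Allyl to 4-Methylbenzyl on the Ring Nitrogen

A few compounds are considered here, and "the series" means these few. Any claim that something is new, unique, unknown or untested is made for them only; others in the source may bear on it.

Compound 1, `O=C1Nc2ccc(-c3ccc(C(F)(F)F)cc3)cc2C1=O`: 5430 nM
Compound 2, `C=CCN1C(=O)C(=O)c2cc(-c3ccc(OC)cc3)ccc21`: 7090 nM

Of the compounds shown here, two have so far been tested in a functional assay on HepG2 cells (Homo sapiens) for antiproliferative activity, read by MTT assay, with a stated time of 48 h; on this read-out higher numbers stand for weaker inhibition and lower numbers for stronger inhibition. Compound 1 gives 5430 nM, and compound 2 gives 7090 nM. Compound 2 has the higher of the two numbers, but its gap to compound 1 lies within the scatter of repeated measurements, so the two cannot be told apart in this assay.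

Compound 3, `COc1ccc(-c2ccc3c(c2)C(=O)C(=O)N3Cc2ccc(C)cc2)cc1`, has not yet been measured in this assay. It differs from compound 2 in a single place: 4-methylphenyl in place of vinyl on a saturated chain carbon bound to an amide-type nitrogen in a ring. The same difference, cut one bond further out, reads allyl to 4-methylbenzyl. Among the compounds with values here, no pair of measured compounds differing in one place is available, so there is no measured step to rest this change on. The two measured values sit close together, and nothing in them points to a large shift from a substitution of this kind. The step is expected to be modest, a 1.6-fold lower number from compound 2 to compound 3 (0.20 log units; within the scatter), at most leaning toward a lower number. Compound 3 is expected to give about 4500 nM, within a range from 1500 nM to 14000 nM.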

Compound 3, half-maximal inhibitory concentration: 330 nM
Beside the measured number, compound 3's estimate is 14-fold (1.13 log units) above it, outside the stated range (below it).
By their numbers in this assay, from the lowest: compound 3; then compounds 1 and 2 (each within the scatter of the next).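

The ring nitrogen turns out to be a place where the substituent matters greatly in this assay: replacing allyl with 4-methylbenzyl, with nothing else changed, gives a 21-fold lower number from compound 2 to compound 3 (1.33 log units; beyond the scatter). Within the data shown here, no earlier pair of measured compounds differing in one place had tested this position, so the two earlier values gave no sign that it could move the number this far. What the change adds is 4-methylphenyl, an aromatic ring of carbon only, in place of vinyl on the saturated chain carbon bound to the nitrogen, but no measurement on hand says why a change of this kind produces a step of this size.

This one pair does not separate the contribution of the aromatic ring from that of its methyl group, so a plain benzyl group on the same nitrogen would be the telling comparison. Also open, on these data alone, is whether the lower number would hold with a longer chain between the nitrogen and the ring, with an amine or a carboxylic acid in place of the methyl group, or on the core of compound 1.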